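Cytotoxicity in mouse cells: a fluoro to methoxy step

The source may hold more compounds than are shown below. What is called first, only, known or untested is meant among the compounds shown, and "the series" means these compounds.

Compound 1 `COc1ccc(C(=O)/C=C/c2ccc(Br)cc2)cc1`: 93700 nM
Compound 2 `COc1ccc(C(/C=C/c2ccc(F)cc2)=N/O)cc1`: 13500 nM
Compound 3 `COc1ccc(C(/C=C/c2cccs2)=N/O)cc1`: 10600 nM

All three compounds were tested in an ADME assay on cells (Mus musculus, strain Balb/c) for cytotoxicity, read by MTT assay, with a stated time of 48 h; on this read-out higher numbers stand for lower toxicity in this test and lower numbers for higher toxicity in this test. Among these three numbers, compound 2 stands second highest. Its nearest neighbour is compound 3, whose number lies within the usual scatter of repeated measurements, so no difference between the two can be claimed. The furthest is compound 1, whose number is higher by a margin beyond the scatter, so compound 1 is less toxic in this test than compound 2.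

Compound 4 `COc1ccc(/C=C/C(=N\O)c2ccc(OC)cc2)cc1` has not yet been measured. It differs from compound 2 in a single place: methoxy in place of fluoro on an aromatic carbon. For the measured compounds named here, no pair of measured compounds differs by exactly this change, so there is no direct precedent for its size. Going by the values given here, the only guide is that compound 2 and compound 3, which share the rest of their structure, give numbers within the scatter of each other. On that basis the step of a 1.1-fold higher number from compound 2 to compound 4 (0.05 log units; within the scatter) is expected to be small, in no clear direction, and not beyond the scatter. Compound 4 is therefore estimated at 15000 nM, with a range from 6000 nM to 40000 nM.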

Compound 4, half-maximal cytotoxic concentration: 2170000 nM
For compound 4 the middle estimate is 140-fold (2.16 log units) below the measured one; measured number outside the range, above it.
By their numbers in this assay, from the lowest: compounds 3 and 2 (each within the scatter of the next); then compound 1; then compound 4.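

For the compounds shown here, until now no pair of compounds showed what a single change could do, and this one shows that the place on the aromatic carbon, para to a large group, matters a great deal. In this assay, methoxy in place of fluoro gives a 160-fold higher number from compound 2 to compound 4 (2.21 log units; beyond the scatter), so compound 4 is far less toxic in this test than compound 2, after a swap of only a few heavy atoms that also brings in one hydrogen-bond acceptor. Nothing measured here explains why the step is so large.

This single pair cannot show whether an amine, a hydroxyl or a longer chain such as ethoxy at the same place would move the number as far as methoxy does. It also leaves open whether the same swap would have a similar effect on a different core.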